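Swapping the aryl group on the shared core of compound 3

The source may hold more compounds than are shown below. What is called first, only, known or untested is meant among the compounds shown, and "the series" means these compounds.

Compound 1 `C=CCn1c(=O)/c(=C\c2cc(Br)ccc2F)[nH]c(=O)/c1=C\c1ccccc1OC`: 12900 nM
Compound 2 `C=CCn1c(=O)/c(=C\c2ccccc2OC)[nH]c(=O)/c1=C\c1ccccc1OC`: 13100 nM
Compound 3 `C=CCn1c(=O)/c(=C\c2ccccc2C(F)(F)F)[nH]c(=O)/c1=C\c1ccccc1OC`: 4400 nM

All three compounds share one core and were tested in a functional assay on MOLT-4 cells (Homo sapiens) for cytotoxicity, read by CCK-8 assay, with a stated time of 72 h; on this read-out higher numbers stand for weaker inhibition and lower numbers for stronger inhibition. Compound 3 stands at the lowest number of the three: the step of a 2.9-fold lower number from compound 1 to compound 3 (0.47 log units; beyond the scatter) and the step of a 3.0-fold lower number from compound 2 to compound 3 (0.47 log units; beyond the scatter) both lie beyond the scatter, whereas the step of a 1.0-fold higher number from compound 1 to compound 2 (0.01 log units; within the scatter) does not. Compound 4 `C=CCn1c(=O)/c(=C\c2cccc(C)c2)[nH]c(=O)/c1=C\c1ccccc1OC` has not yet been measured. It differs from compound 3 in one place: 3-methylphenyl in place of 2-(trifluoromethyl)phenyl on a double-bonded chain carbon bound to an aromatic carbon. Going by the values given here, no measured step replaces the 2-(trifluoromethyl)phenyl group by a 3-methylphenyl group, so there is no direct precedent. The two steps that bear on the change, a 2.9-fold lower number from compound 1 to compound 3 (0.47 log units; beyond the scatter) and a 3.0-fold lower number from compound 2 to compound 3 (0.47 log units; beyond the scatter), show that the 2-(trifluoromethyl)phenyl group sits at a modestly lower number than either of the other two aryl groups tried on the same chain carbon, and both of those other groups gave numbers within the scatter of each other. Leaving this group is therefore expected to move compound 4 back toward the higher numbers of the other aryl groups, but with wide uncertainty. Compound 4 is expected to give about 9000 nM, between 3500 nM and 25000 nM, which is an expected step of a 2.0-fold higher number from compound 3 to compound 4 (0.31 log units; beyond the scatter).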

Compound 4, half-maximal inhibitory concentration: 16000 nM
Beside the measured number, compound 4's estimate is 1.8-fold (0.25 log units) below it, and the stated range covers the measured number.
By their numbers in this assay, from the lowest: compound 3; then compounds 1, 2 and 4 (each within the scatter of the next).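

In this assay, the 3-methylphenyl group places compound 4 with the other aryl compounds rather than with compound 3: the step of a 3.6-fold higher number from compound 3 to compound 4 (0.56 log units; beyond the scatter) lies beyond the scatter, whereas the steps of a 1.2-fold higher number from compound 2 to compound 4 (0.09 log units; within the scatter) and a 1.2-fold higher number from compound 1 to compound 4 (0.09 log units; within the scatter) lie within it. Three different aryl groups on this double-bonded chain carbon, bearing methyl, methoxy, or bromine and fluorine, now stand within the scatter of one another, and compound 3, with its 2-(trifluoromethyl)phenyl group, is the only one of the four that stands apart. No measurement shown here accounts for the separate standing of compound 3.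

Compound 3 and compound 4 differ both in the substituent and in the name-given ring position it occupies, so the compounds shown cannot separate these two changes; a 3-(trifluoromethyl)phenyl or a 2-methylphenyl group on the same chain carbon would bear on that question. As far as these compounds go, it also remains open how a phenyl group carrying an amine or a carboxylic acid would stand against compound 3 in this assay on this read-out.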